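4-methylphenyl in place of 2-methoxybenzyl

The compounds below may be only part of what the source reports. "The series", "measured", "known", "first", "only" and "open" are said of these compounds alone.

Compound 1 `CN1CCN(c2ccc(Nc3ncc(Cl)c(NCc4ccccc4)n3)nc2)CC1` gives 17300 nM
Compound 2 `COc1ccccc1CNc1nc(Nc2ccc(N3CCN(C)CC3)cn2)ncc1Cl` gives > 100000 nM (a limit, not a number)

Both results come from a functional assay on MCF7 cells (Homo sapiens) for inhibition, read by CCK-8 assay, with a stated time of 48 h (a lower number here means a stronger inhibitor of growth, a higher number a weaker inhibitor of growth), and they are the only ones so far. Compound 2 stands at the limit of > 100000 nM in this assay, at which 1 of the 2 values shown sits, and so has no number of its own.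

Compound 3 `Cc1ccc(Nc2nc(Nc3ccc(N4CCN(C)CC4)cn3)ncc2Cl)cc1` differs from compound 2 in one place (4-methylphenyl in place of 2-methoxybenzyl on a nitrogen on an aromatic ring) and carries 4-methylphenyl in place of 2-methoxybenzyl on a nitrogen on an aromatic ring. Among the compounds with values here, the one measured step that bears on this is an at least 5.7-fold higher number from compound 1 to compound 2 (0.76 log units; beyond the scatter) for methoxy in place of hydrogen on an aromatic carbon, and compound 3 no longer has that methoxy. Within the data shown here, no measured step covers the rest of the change. Given an at least 5.7-fold higher number from compound 1 to compound 2 (0.76 log units; beyond the scatter) as the only guide, a move to a lower number in this assay is expected, though another limit remains possible. The expected step is an at least 5.0-fold lower number from compound 2 to compound 3 (0.69 log units; beyond the scatter) and it is only an estimate. For compound 3 the estimated value is 20000 nM with an expected range from 5000 nM to 80000 nM at its two ends.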

Compound 3, concentration for 50% growth inhibition: 11400 nM
Compound 3: middle estimate off by 1.8-fold (0.24 log units), on the high side; the measured number falls inside the stated range.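

In this assay, 4-methylphenyl in place of 2-methoxybenzyl on this nitrogen gives a measurable value, with an at least 8.7-fold lower number from compound 2 to compound 3 (0.94 log units; beyond the scatter). Compound 2 has a limit rather than a number, so that step gives only a minimum size: the limit of > 100000 nM in this assay, at which 1 of the 3 values shown sits. Against benzyl, the same position shows a 1.5-fold lower number from compound 1 to compound 3 (0.18 log units; within the scatter), so benzyl and 4-methylphenyl cannot be told apart here, and among these three compounds only the 2-methoxybenzyl of compound 2 stands apart.

The compounds shown leave open whether the link between the nitrogen and the ring matters at all, since benzyl has one and 4-methylphenyl does not, and these two groups also differ in their methyl. A plain phenyl or a longer chain such as phenethyl on this nitrogen would help separate those two changes.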